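Chloro in Place of Hydrogen in Two Related Pairs

The source may report more compounds than this note shows. Statements on the series, on what has been measured and on what is new or still open speak of the compounds shown alone.

Compound 1, `O=C(Nc1ccc([N+](=O)[O-])cc1)c1cc(F)ccc1O`: 2080 nM
Compound 2, `N#Cc1ccc(NC(=O)c2ccc3cccnc3c2O)cc1`: 130 nM
Compound 3, `N#Cc1ccc(NC(=O)c2ccc3cccnc3c2O)c(Cl)c1`: 420 nM

Of the compounds shown here, three have been measured in a functional assay on NALM-6 cells (Homo sapiens) for cytotoxicity, read by luminescence and CellTiter-Glo, with a stated time of 3 days; on this read-out higher numbers stand for weaker inhibition and lower numbers for stronger inhibition. Compound 2 gives 130 nM, the lowest of the three numbers. Compound 3 differs from compound 2 by chloro in place of hydrogen on an aromatic carbon, and this change gave a 3.2-fold higher number from compound 2 to compound 3 (0.51 log units; beyond the scatter). Compound 1 gives 2080 nM in this assay, the highest number of the three; the difference between its core and the shared core of compound 2 and compound 3 is not broken down here.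

Compound 4, `O=C(Nc1ccc([N+](=O)[O-])cc1Cl)c1cc(F)ccc1O`, has not yet been measured. It differs from compound 1 by chloro in place of hydrogen on an aromatic carbon. Going by the values given here, this is the same kind of change as that from compound 2 to compound 3, not the same: in the one pair the new chloro sits meta to a cyano group, in the other it sits meta to a nitro group, and the two cores differ as well.

Among the compounds with values here, the step from compound 2 to compound 3 is the only measured guide. Compound 4 is therefore expected to give a number higher than compound 1 by a step like a 2.9-fold higher number from compound 1 to compound 4 (0.46 log units; beyond the scatter), because the same kind of change produced a 3.2-fold higher number from compound 2 to compound 3 (0.51 log units; beyond the scatter). On that basis compound 4 is estimated at 6000 nM in this assay, with a range from 2500 nM to 15000 nM to allow for the different surroundings of the change.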

Compound 4, half-maximal inhibitory concentration: 910 nM
Estimate against measurement, compound 4: 6.6-fold (0.82 log units) above, outside the stated range (below it).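

In this assay, chloro in place of hydrogen on an aromatic carbon gave a 2.3-fold lower number from compound 1 to compound 4 (0.36 log units; beyond the scatter), so the rise seen on the core of compound 2 did not recur on the core of compound 1. Set side by side, the two steps run in opposite directions, and the gap between them is larger than repeated measurement would explain: the same change on two cores in this assay, a 3.2-fold higher number (0.51 log units; beyond the scatter) from compound 2 to compound 3 and a 2.3-fold lower number (0.36 log units; beyond the scatter) from compound 1 to compound 4, 7.4-fold (0.87 log units) apart, beyond the scatter of two such steps. This shows that, across these two pairs, neither the size nor the direction of the change can be carried from one core to the other, but it does not show what sets the two outcomes apart, as the pairs differ both in their cores and in having a cyano or a nitro group on the ring that takes the chloro.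

The compounds shown leave open whether the direction of the step follows the core or that cyano or nitro group, a question that a nitrile in place of the nitro group on the core of compound 1 would bear on. They also leave open whether a methyl or a methoxy group in place of the chloro, or an amine or a carboxylic acid in place of the nitro group of compound 4, would change the number in this assay.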